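A few compounds are considered here, and "the series" means these few. Any claim that something is new, unique, unknown or untested is made for them only; others in the source may bear on it.

In a functional assay on A549 cells (Homo sapiens) for inhibition, read by MTT assay, with a stated time of 24 h (a higher number here means a weaker inhibitor of growth, a lower number a stronger inhibitor of growth), compound 1 `Cn1cc(-c2nc3ccccc3n2C(=O)c2ccccc2)c2ccccc21` gives 19600 nM and compound 2 `COc1cccc(C(=O)n2c(-c3cn(C)c4ccccc34)nc3ccccc32)c1` gives 10200 nM. Compound 3 `COc1ccc2c(c1)c(-c1nc3ccccc3n1C(=O)c1ccccc1)cn2C` gives 16700 nM, and all three values lie within the scatter of one another, so compound 3 has no clear rank in this small set.

The next compound is compound 4 `COc1ccc2c(c1)c(-c1nc3ccccc3n1C(=O)c1ccccc1Br)cn2C`, and the change is bromo in place of hydrogen on an aromatic carbon, which turns benzoyl into (2-bromophenyl)carbonyl. Going by the values given here, no measured pair involves bromo, so only methoxy in place of hydrogen offers any guidance. Among the compounds with values here, on the benzoyl group, the one that changes here, that replacement gives a 1.9-fold lower number from compound 1 to compound 2 (0.28 log units; within the scatter). Elsewhere on the shared core it gives a 1.2-fold lower number from compound 1 to compound 3 (0.07 log units; within the scatter). Within the data shown here, both steps stay within the scatter, so neither establishes a real effect of substitution, and the one on the benzoyl group gives only a weak hint of direction.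

No step beyond the scatter is therefore expected in this assay, with a slightly lower number at most a tentative lean. The estimated step is a 1.3-fold lower number from compound 3 to compound 4 (0.13 log units; within the scatter). For compound 4 the expected value is 12500 nM, with an estimated range of 5500 nM to 27000 nM.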

Compound 4, concentration for 50% growth inhibition: 29500 nM
The estimate for compound 4 lay 2.4-fold (0.37 log units) below the measured number; measured number outside the range, above it.
By their numbers in this assay, from the lowest: compounds 2, 3, 1 and 4 (each within the scatter of the next, the first and the last beyond it).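

In this assay, bromo in place of hydrogen, on an aromatic carbon ortho to a large group, turns benzoyl into (2-bromophenyl)carbonyl and gives a 1.8-fold higher number from compound 3 to compound 4 (0.25 log units; within the scatter), so this replacement does not establish a real effect at this place. Going by these compounds alone, this is the first information on a halogen and on this place on the benzoyl group, as the earlier steps covered methoxy alone, and none of the three single-place steps now available lies beyond the scatter. Nothing available here offers an explanation for the size or direction of this step.

The compounds shown leave open whether any replacement at this place on the benzoyl group can produce a step beyond the scatter, for instance fluoro, chloro, an amine or a carboxylic acid. They also leave open whether bromo would give a comparable step on the core of compound 1, without the methoxy group carried by compound 3 and compound 4, or on another carbon of the benzoyl ring.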